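The source may hold more compounds than are shown below. What is called first, only, known or untested is meant among the compounds shown, and "the series" means these compounds.

The measured compounds:

Compound 1, `CCOC(=O)c1[nH]c2cc(Cl)ccc2c1/C=N/NC(=O)Cc1ccccc1`, gives in an assay for inhibition of Polyunsaturated fatty acid lipoxygenase ALOX15 (Homo sapiens), with a stated time of 8 min (on this read-out lower numbers stand for stronger inhibition and higher numbers for weaker inhibition), a result of > 10000 nM, which is a limit of the assay and not a number.
Compound 2, `CCOC(=O)c1[nH]c2cc(Cl)ccc2c1/C=N/NC(=O)COc1ccc([N+](=O)[O-])cc1`, gives in this assay a result of > 10000 nM, again a limit.
Compound 3, `CCOC(=O)c1[nH]c2cc(Cl)ccc2c1/C=N/NC(=O)COc1cccc2ccccc12`, gives in this assay a result of > 10000 nM, also a limit.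

Compound 3 therefore stands at the edge of what this assay can report, and the whole series shares that position, since (the limit of > 10000 nM in this assay, at which 3 of the 3 values shown sit). The two measured steps, a step that the two limits leave unreadable from compound 1 to compound 2 and a step that the two limits leave unreadable from compound 2 to compound 3, cannot be sized for the same reason, so they show neither gain nor loss.

The compound not yet measured, compound 4, `CCOC(=O)c1[nH]c2cc(Cl)ccc2c1/C=N/NC(=O)COc1ccccc1`, differs from compound 3 by phenyl in place of naphthalen-1-yl on an oxygen on a saturated carbon. Both measured steps changed the group on the same oxygen and left the value at the limit, so the step that the limit leaves unreadable from compound 3 to compound 4 is expected to carry compound 4 no further than the scatter. Compound 4 is expected to give 20000 nM in this assay, with a range from 7000 nM to 60000 nM.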

Compound 4, half-maximal inhibitory concentration: > 10000 nM
Compound 4 ended at the assay's limit; the forecaster's own chance of this, stated with the estimate: 85%; the middle value does not contradict the limit.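

For the compounds shown here, compound 1, compound 2, compound 3 and compound 4 all end at a limit and not at a number, so no step among them can be read: the limit of > 10000 nM in this assay, at which 4 of the 4 values shown sit. The compounds shown leave open how strongly each one inhibits, and whether changing these groups alters that strength at all.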